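Trimming a Side Chain: Isobutyl Gives Way to Isopropyl

A few compounds are considered here, and "the series" means these few. Any claim that something is new, unique, unknown or untested is made for them only; others in the source may bear on it.

Of the compounds shown here, two that share one core have been measured in a functional assay on the whole organism (Tail, strain ICR) with Mus musculus as the target, in the tail flick test, with a stated time of 150 min, at a dose of 25 umol/kg by the oral route; a higher number here means a stronger effect of the compound at the dose given, a lower number a weaker effect. Compound 1 `CC(C)(C)OC(=O)NCCCC[C@H](NC(=O)CN(c1ncnc2c1ncn2C1CCCCO1)C1CC1)C(=O)OCc1ccccc1` gives 17.2% there, and compound 2 `CC(C)C[C@H](NC(=O)CN(c1ncnc2c1ncn2C1CCCCO1)C1CC1)C(=O)OCc1ccccc1` gives 6.47%, which is the lower of the two numbers. Among the measured compounds shown here, the single measured step, a number 10.7 percentage points lower from compound 1 to compound 2 (beyond the scatter), is a modest fall.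

Compound 3 `CC(C)[C@H](NC(=O)CN(c1ncnc2c1ncn2C1CCCCO1)C1CC1)C(=O)OCc1ccccc1` has not yet been measured. It differs from compound 2 in one place: isopropyl in place of isobutyl on a saturated chain carbon bound to an amide-type nitrogen and a carbonyl carbon. For the measured compounds named here, this alters the same side chain that was altered in the only measured step, but with a different pair of groups, so that step gives only a loose guide. The swap itself is small, one carbon fewer in a branched chain, and nothing measured here points to a shift in either direction. The expectation for compound 3 in this assay is therefore a step no larger than the usual scatter, with the estimated change being a number 0.5 percentage points higher from compound 2 to compound 3 (within the scatter). Compound 3 is thus estimated at 7%, with a plausible range from 0% to 18%.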

Compound 3, a percentage reported as activity, at one dose (the size of the read-out at that dose, not a potency): 21.1%
The estimate for compound 3 lay 14.1 percentage points below the measured number, outside the stated range (above it).
By their numbers in this assay, from the lowest: compound 2; then compounds 1 and 3 (each within the scatter of the next).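

In this assay the swap of isobutyl for isopropyl, which gives a number 14.6 percentage points higher from compound 2 to compound 3 (beyond the scatter), shows that even a small change to the side chain on this saturated chain carbon, bound to an amide-type nitrogen and a carbonyl carbon, can move the read-out beyond the usual scatter. The very different 4-((tert-butoxycarbonyl)amino)butyl group and isopropyl cannot be told apart here, with a number 3.9 percentage points higher from compound 1 to compound 3 (within the scatter), so among these three compounds the number does not simply follow the size of the side chain, and compound 2 alone stands lowest. Nothing available explains why the isobutyl compound differs from the other two.

On these data alone, with only three side chains, it remains open whether isobutyl is an isolated low point or part of a wider trend that other groups, such as a plain methyl, a cyclohexyl ring or a free amine on a longer chain, would reveal. Each number also describes a single oral dose at a single time, so these compounds could still compare differently at other doses or times.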